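The source may report more compounds than this note shows. Statements on the series, on what has been measured and on what is new or still open speak of the compounds shown alone.

Series notes. Compound 3 `Fc1ccc2nc(NC(=S)Nc3ccc(Cl)cc3)sc2c1` gives 31200 nM in a functional assay on THP-1 cells (Homo sapiens) for cytotoxicity, read by MTT assay, with a stated time of 48 h; on this read-out lower numbers stand for stronger inhibition and higher numbers for weaker inhibition. Compound 1 `S=C(Nc1ccc(Cl)cc1)Nc1nc2ccccc2s1`, which carries the change (hydrogen in place of fluoro on an aromatic carbon), gives 39000 nM; the step is a 1.3-fold higher number from compound 3 to compound 1 (0.10 log units; within the scatter). Compound 2 `CCOc1ccc2nc(Nc3nc4ccc(F)cc4s3)sc2c1` gives 39000 nM and stands level with compound 1 at the digits reported, with compound 3 the furthest of the three. The difference between the core of compound 2 and that of compound 3 is not broken down here.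

Compound 4 `CCOc1ccc2nc(Nc3nc4ccccc4s3)sc2c1` is not yet measured. It differs from compound 2 by hydrogen in place of fluoro on an aromatic carbon, the same change as from compound 3 to compound 1; it occurs twice in the set, with the place described in the same words both times. Starting from compound 2 at 39000 nM, an estimated step of a 1.2-fold higher number from compound 2 to compound 4 (0.06 log units; within the scatter) is expected beside a 1.3-fold higher number from compound 3 to compound 1 (0.10 log units; within the scatter), resting on that single earlier step. For compound 4 the expected value is therefore 45000 nM, roughly between 25000 nM and 80000 nM.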

Compound 4, half-maximal inhibitory concentration: 37100 nM
The estimate for compound 4 lay 1.2-fold (0.08 log units) above the measured number, within the range that was stated.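

Swapping fluoro for hydrogen on an aromatic carbon gives a 1.1-fold lower number from compound 2 to compound 4 (0.02 log units; within the scatter) in this assay. Set beside the earlier step, the change reads alike on both cores: the same change on two cores in this assay, a 1.3-fold higher number (0.10 log units; within the scatter) from compound 3 to compound 1 and a 1.1-fold lower number (0.02 log units; within the scatter) from compound 2 to compound 4, 1.3-fold (0.12 log units) apart, within the scatter of two such steps. This shows that, on these two cores, the change carries over without a step beyond the scatter; it gives no direction for the change and does not show that the same would hold on any other core.

The compounds shown leave open whether a different group in that place, such as an amine or a carboxylic acid, would move the number beyond the scatter. From the compounds shown here alone, whether a longer chain in place of the ethoxy group of compound 4 would do so also stays open.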